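Amide variation on the shared core: expectation for compound 3

The source may report more compounds than this note shows. Statements on the series, on what has been measured and on what is new or still open speak of the compounds shown alone.

compound 1, `O=C(N1CCC(F)CC1)N1CC(c2nc(-c3cccc(Cl)c3)no2)C1`, in an assay on HEK293 cells for negative allosteric modulation of metabotropic glutamate receptor 5 (Homo sapiens), read by FLIPR; a higher number here means a weaker inhibitor, a lower number a stronger inhibitor: > 10000 nM, a limit of the assay
compound 2, `O=C(C1CCC(F)(F)CC1)N1CC(c2nc(-c3cccc(Cl)c3)no2)C1`, in this assay: > 10000 nM, a limit of the assay

Compound 2 stands only at a limit in this assay and cannot be ordered against compound 1. Compound 3 is `O=C(c1ccccc1F)N1CC(c2nc(-c3cccc(Cl)c3)no2)C1`; its change from compound 2 is 2-fluorophenyl in place of 4,4-difluorocyclohexyl on a carbonyl carbon. Within the data shown here, the only measured step, a step that the two limits leave unreadable from compound 1 to compound 2, is unreadable because of the limit of > 10000 nM in this assay, at which 2 of the 2 values shown sit. Among the measured compounds shown here, no measured step therefore bears on the present change. Compound 3 is expected at 3000 nM, in the range 300 nM to 10000 nM. The step of an at least 3.3-fold lower number from compound 2 to compound 3 (0.52 log units; beyond the scatter) is an expected one, read from a limit.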

Compound 3, half-maximal inhibitory concentration: 670 nM
Estimate against measurement, compound 3: 4.5-fold (0.65 log units) above; measured number inside the range.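

Among these compounds, on the carbonyl carbon of the shared core, 2-fluorophenyl is the first group to give a number rather than a limit in this assay. Against the saturated 4,4-difluorocyclohexyl it gives an at least 14-fold lower number from compound 2 to compound 3 (1.17 log units; beyond the scatter), and against the 4-fluoropiperidin-1-yl amide it gives an at least 14-fold lower number from compound 1 to compound 3 (1.17 log units; beyond the scatter). Both steps are bounds only, and the step between compound 1 and compound 2 cannot be read: the limit of > 10000 nM in this assay, at which 2 of the 3 values shown sit.

On these data alone, whether the aromatic ring alone carries this step, or its fluorine also contributes, stays open. Unsubstituted phenyl or pyridin-2-yl on the same carbonyl carbon would separate the two.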